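Furan for thiophene on the methoxy nucleoside series

The source may report more compounds than this note shows. Statements on the series, on what has been measured and on what is new or still open speak of the compounds shown alone.

Within the data shown here, compound 1 `COc1ncnc2c1c(-c1ccsc1)cn2[C@@H]1O[C@H](CO)[C@@H](O)[C@H]1O` is the only member of the set with a number in a functional assay on HeLa S3 cells (Homo sapiens) for antiproliferative activity, read by XTT assay, with a stated time of 72 h; on this read-out lower numbers stand for stronger inhibition and higher numbers for weaker inhibition: compound 1 gives 3350 nM. Compound 2 `O=c1[nH]cnc2c1c(-c1ccoc1)cn2[C@@H]1O[C@H](CO)[C@@H](O)[C@H]1O` also carries furan-3-yl, and in this assay compound 2 reaches only a limit, > 20000 nM. Compound 3 `CN(C)c1ncnc2c1c(-c1ccsc1)cn2[C@@H]1O[C@H](CO)[C@@H](O)[C@H]1O` likewise stops at a limit in this assay, > 15000 nM. Among the measured compounds shown here, the one measured step, an at least 4.4-fold higher number from compound 1 to compound 3 (0.65 log units; beyond the scatter), shows that replacing methoxy by dimethylamino costs activity, and it is read against a limit (the limit of > 15000 nM in this assay, at which 1 of the 3 values shown sits).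

Compound 4 `COc1ncnc2c1c(-c1ccoc1)cn2[C@@H]1O[C@H](CO)[C@@H](O)[C@H]1O` keeps the methoxy group of compound 1 and differs from it only in the five-membered ring: furan-3-yl in place of thiophen-3-yl on an aromatic carbon. For the measured compounds named here, no measured step touches this exchange. Compound 2 shares furan-3-yl with compound 4 but differs elsewhere, and compound 2 sits at a limit (the limit of > 20000 nM in this assay, at which 1 of the 3 values shown sits), so it sets no number to compare against. Thiophen-3-yl and furan-3-yl match in heavy-atom count and in donor and acceptor count, so for compound 4 in this assay a step within the scatter, or slightly toward a higher number, is expected: a 1.5-fold higher number from compound 1 to compound 4 (0.17 log units; within the scatter). The estimate for compound 4 is 5000 nM, with a range from 2000 nM to 15000 nM.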

Compound 4, half-maximal inhibitory concentration: 1790 nM
Estimate against measurement, compound 4: 2.8-fold (0.45 log units) above; the whole stated range lies above it.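

Among these compounds, on the aromatic carbon two ring bonds from the ring nitrogen, with methoxy held constant, the exchange of thiophen-3-yl for furan-3-yl gives the only step at this position in this assay: a 1.9-fold lower number from compound 1 to compound 4 (0.27 log units; within the scatter). Among the compounds shown here, compound 2, which also carries furan-3-yl, gives only a limit, > 20000 nM, so compound 4 supplies the only number for furan-3-yl in the set, and on the methoxy nucleoside this read-out does not separate the two five-membered rings. No measured property in hand bears on this step, so the result stands as an activity reading without an explanation.

Still open, from the compounds shown here alone, is whether this position accepts groups other than these two rings, such as phenyl, furan-2-yl or an aminomethyl chain, with a similar reading in this assay. Also open, going by these compounds, is whether the loss seen with thiophen-3-yl on going from methoxy to dimethylamino, an at least 4.4-fold higher number from compound 1 to compound 3 (0.65 log units; beyond the scatter), recurs when furan-3-yl occupies this carbon.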